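A few compounds are considered here, and "the series" means these few. Any claim that something is new, unique, unknown or untested is made for them only; others in the source may bear on it.

The two compounds measured so far, with their numbers in an ADME assay for permeability, using PAMPA, at pH 7.4; a higher number here means that the compound crosses the layer faster, a lower number that the compound crosses the layer more slowly:

compound 1, `Cc1cc(NC(=O)Nc2ccc(C(C)(C)C)cc2)c2ccccc2n1`: 142 10^-6 cm/s
compound 2, `Cc1cc(NC(=O)Nc2ccccc2C(C)(C)C)c2ccccc2n1`: 27 10^-6 cm/s

Compound 1 stands highest of the two numbers. Its nearest neighbour is compound 2, whose number is lower by a margin beyond the usual scatter, so the order of these two compounds is secure. Among the measured compounds shown here, no pair of measured compounds that differ in a single place is available, so the effect of a single change has not yet been seen directly.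

Compound 3, `Cc1cc(NC(=O)Nc2ccc(OC(F)(F)F)cc2)c2ccccc2n1`, has not yet been measured in this assay. It differs from compound 1 in one place: trifluoromethoxy in place of tert-butyl on an aromatic carbon.

For the measured compounds named here, with no measured single-place step to lean on, the account can only anticipate the outcome. The step of a 1.4-fold lower number from compound 1 to compound 3 (0.15 log units; within the scatter) is expected to be a modest decrease, one that stays within the usual scatter rather than beyond it. Compound 3 is therefore estimated at 100 10^-6 cm/s, with a range from 50 10^-6 cm/s to 200 10^-6 cm/s.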

Compound 3, apparent permeability: 531 10^-6 cm/s
For compound 3 the middle estimate is 5.3-fold (0.73 log units) below the measured one; measured number above the stated range.
By their numbers in this assay, from the lowest: compound 2; then compound 1; then compound 3.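

In this assay, the series now has its first directly measured single-place step: trifluoromethoxy in place of tert-butyl on an aromatic carbon, para to a large group, gives a 3.7-fold higher number from compound 1 to compound 3 (0.57 log units; beyond the scatter). This shows that the number is sensitive to the group at this position even with the rest of compound 1 unchanged, as an all-carbon group gives way to one that brings in oxygen, fluorine and a hydrogen-bond acceptor. Among the compounds shown here, nothing measured so far explains why the number rises with this change.

This single step cannot show whether the rise follows from the oxygen, from the fluorines or from the trifluoromethoxy group as a whole, and it does not show how far the trend extends beyond this pair. A methoxy or a trifluoromethyl group in the same place would help to separate these parts, while an amine or a carboxylic acid there would test whether the number holds up with a very different kind of group.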